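Methoxy for methyl on the core of compound 1

This account rests on a few compounds, and the source may have more. Where it says the series, first, only, none or still open, it means among the compounds named here.

In an ADME assay on microsomes from liver (Mus musculus) for metabolic stability (on this read-out lower numbers stand for slow clearance and higher numbers for fast clearance), compound 1 (`Cc1cc(Cl)ccc1-c1ccc(N2CCc3c(C)ccc(N4CCN(C)CC4)c3C2)nc1`) gives 0.035 mL/min/kg and lies within the scatter of compound 2 (`Cc1ccc(N2CCN(C)CC2)c2c1CCN(c1ccc(-c3ccc(C(C)(C)C)cc3)cn1)C2`), which gives 0.056 mL/min/kg on the same read-out. Among the measured compounds shown here, these are the only two measured compounds. Compound 3 (`COc1ccc(N2CCN(C)CC2)c2c1CCN(c1ccc(-c3ccc(Cl)cc3C)cn1)C2`) differs from compound 1 by methoxy in place of methyl on an aromatic carbon in one place: methoxy in place of methyl on an aromatic carbon, para to a 4-methylpiperazin-1-yl group. For the measured compounds named here, the one measured step puts 4-(tert-butyl)phenyl in place of 4-chloro-2-methylphenyl, at a different place, and a 1.6-fold higher number from compound 1 to compound 2 (0.20 log units; within the scatter) stays within the scatter. Going by the values given here, no measured step covers the methyl-to-methoxy change, so it bears only loosely on this comparison. In this assay the expected result is a 1.3-fold higher number from compound 1 to compound 3 (0.11 log units; within the scatter) as an estimate, which is no step beyond the scatter and has no firm direction. For compound 3 the estimated clearance is 0.045 mL/min/kg with an expected range from 0.015 mL/min/kg to 0.13 mL/min/kg on this read-out.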

Compound 3, clearance: 0.042 mL/min/kg
Estimate against measurement, compound 3: 1.1-fold (0.03 log units) above, within the range that was stated.
By their numbers in this assay, from the lowest: compounds 1, 3 and 2 (each within the scatter of the next).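

On the aromatic carbon para to a 4-methylpiperazin-1-yl group, methoxy in place of methyl gives a 1.2-fold higher number from compound 1 to compound 3 (0.08 log units; within the scatter) in this assay, with the rest of the molecule unchanged. Among the compounds shown here, the earlier step touched only the 4-chloro-2-methylphenyl group, whereas this one gives the first reading at this position on the shared core: here, the extra oxygen and its hydrogen-bond acceptor come with a number that stays within the scatter. Nothing available gives a reason for this result.

Open, from the compounds shown here alone, is whether the same holds with the 4-(tert-butyl)phenyl group of compound 2 in place of the 4-chloro-2-methylphenyl group. Also open is how this position responds to an ethoxy group, an amine or a carboxylic acid, since methyl and methoxy are the only two groups shown there.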